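The source may report more compounds than this note shows. Statements on the series, on what has been measured and on what is new or still open speak of the compounds shown alone.

Three amides built on one shared core have been tested in a functional assay on the whole organism (strain Wistar) for inhibition, with Rattus norvegicus as the target, read by paw edema, with stated times of 60 min and 4 h, at a dose of 100 mg/kg by the oral route; on this read-out lower numbers stand for less inhibition and higher numbers for more inhibition at the one dose given (going by the name of the read-out). Compound 1 `COc1cc2c(cc1OC)C(CC(=O)NC(C)C)CC2` gives 39.1%. Compound 2 `COc1cc2c(cc1OC)C(CC(=O)NC(C)(C)C)CC2` gives 32.8%. Compound 3 `CCCCCNC(=O)CC1CCc2cc(OC)c(OC)cc21` gives 40.6%. Compound 2 arises from compound 1 by methyl in place of hydrogen on a saturated chain carbon bound to an amide-type nitrogen and two saturated chain carbons, and that change made a step of a number 6.3 percentage points lower from compound 1 to compound 2 (within the scatter). Compound 3 arises from compound 1 by pentyl in place of isopropyl on an amide-type nitrogen, a step of a number 1.5 percentage points higher from compound 1 to compound 3 (within the scatter). Compound 2 and compound 3 are separated by a number 7.8 percentage points higher from compound 2 to compound 3 (within the scatter). Compound 4 `CCCCCCNC(=O)CC1CCc2cc(OC)c(OC)cc21` has not yet been measured; it differs from compound 3 by methyl in place of hydrogen on a saturated chain carbon, five bonds along the chain from an amide-type nitrogen. For the measured compounds named here, this is the same kind of change as the one from compound 1 to compound 2, but not the same: there the methyl entered on a saturated chain carbon bound to an amide-type nitrogen and two saturated chain carbons, here it enters on a saturated chain carbon, five bonds along the chain from an amide-type nitrogen. Because the earlier step was a number 6.3 percentage points lower from compound 1 to compound 2 (within the scatter) and all three measured values sit within the scatter of one another, a step of a number 0.4 percentage points higher from compound 3 to compound 4 (within the scatter) is expected. Compound 4 is therefore estimated at 41% in this assay, with a likely range from 30% to 52%.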

Compound 4, a percentage reported as inhibition, in the whole organism at one dose (the size of the read-out at that dose, not a potency): 42.1%
For compound 4 the middle estimate is 1.1 percentage points below the measured one, within the range that was stated.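

In this assay, methyl in place of hydrogen on a saturated chain carbon, five bonds along the chain from an amide-type nitrogen, gives a number 1.5 percentage points higher from compound 3 to compound 4 (within the scatter) and leaves hexyl on that nitrogen with a number 9.3 percentage points higher from compound 2 to compound 4 (within the scatter) and with a number 3 percentage points higher from compound 1 to compound 4 (within the scatter) as the other two readings. Set beside the earlier methyl step, this one does not differ from it, so on these numbers the change reads alike on both cores: the same change on two cores in this assay, a number 6.3 percentage points lower (within the scatter) from compound 1 to compound 2 and a number 1.5 percentage points higher (within the scatter) from compound 3 to compound 4, 7.8 percentage points apart, within the scatter of two such steps. This does not show that the change carries over with a fixed size or direction, since every step here lies within the scatter and the methyl enters at a different place in each case.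

The compounds shown leave open whether a longer chain than hexyl, or a phenyl ring on the amide-type nitrogen, would give a number beyond the scatter. They also leave open what an amine or a carboxylic acid at the far end of the chain would do to the read-out.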